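Amide nitrogen substituents on a shared core and A2b binding

A few compounds are considered here, and "the series" means these few. Any claim that something is new, unique, unknown or untested is made for them only; others in the source may bear on it.

Measured compounds:
compound 1, `COCCNC(=O)c1cc2cccc(OC)c2oc1=N`, 43%
compound 2, `COc1cccc2cc(C(=O)NC3CCCCC3)c(=N)oc12`, > 70%

In an assay on HEK293 cells for displacement of a labelled ligand from adenosine receptor A2b (Homo sapiens), read by scintillation counting, with a stated time of 30 min, tested at 10 uM (on this read-out lower numbers stand for less inhibition and higher numbers for more inhibition at the one concentration tested (going by the name of the read-out)), compound 1 gives 43%. In this assay compound 2 gives > 70%, which is a limit of the assay rather than a number. Compound 2 therefore stands at the top of the values shown, consistent with the limit of > 70% in this assay, at which 1 of the 2 values shown sits. Among the measured compounds shown here, the one measured step, a number at least 27 percentage points higher from compound 1 to compound 2 (beyond the scatter), exchanged an open, oxygen-bearing chain for a carbocyclic ring on the amide-type nitrogen and raised inhibition beyond the scatter.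

Compound 3, `COc1cccc2cc(C(=O)NCCCCCO)c(=N)oc12`, has not yet been measured in this assay. It differs from compound 2 by 5-hydroxypentyl in place of cyclohexyl on an amide-type nitrogen. This change runs in the opposite sense to the measured step: a ring of carbon only leaves and a chain bearing a hydroxyl enters on the same nitrogen. On that basis a drop in inhibition from compound 2 to compound 3 of modest size is expected, a number at least 20 percentage points lower from compound 2 to compound 3 (beyond the scatter), while the open-chain oxygen-bearing compound 1 shows where such analogues have landed. Compound 3 is estimated to give 50%, with a range from 30% to 72%.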

Compound 3, a percentage reported as inhibition, at one concentration (the size of the read-out at that concentration, not a potency): > 70%
Compound 3 gave a limit, no number; the forecaster's own chance of this, stated with the estimate: 15%; at least 20 percentage points between middle value and limit.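

In this assay compound 3 gives > 70%, which is a limit of the assay and not a number. A ring of carbon only is therefore not required on this amide-type nitrogen to reach the top of the values shown, and an open chain bearing oxygen does not by itself keep inhibition low: the exchange of the methoxy end of the chain for 3-hydroxypropyl gives a number at least 27 percentage points higher from compound 1 to compound 3 (beyond the scatter). The step from cyclohexyl to 5-hydroxypentyl cannot be read, so the earlier reading of the ring as the better group no longer stands on these values, and the two groups cannot be placed in any order: the limit of > 70% in this assay, at which 2 of the 3 values shown sit.

The compounds shown do not tell how far compound 2 and compound 3 each lie past that limit, and so leave open any ranking of the two. They also leave open whether the hydroxyl of the 5-hydroxypentyl chain matters at all, which a plain pentyl chain would test, and whether an amine or a carboxylic acid in place of that hydroxyl would stay at the same limit.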